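A few compounds are considered here, and "the series" means these few. Any claim that something is new, unique, unknown or untested is made for them only; others in the source may bear on it.

Among the measured compounds shown here, compound 3 `COc1ccc(/C=C/C[C@@H]2C[C@H]([C@H](O)c3ccc(OC)c(OC)c3)CO[C@H]2c2ccc(OC)c(OC)c2)cc1OC` is one of three compounds measured in a functional assay on HeLa cells (Homo sapiens) for cytotoxicity, read by WST assay, with a stated time of 48 h; a higher number here means a weaker inhibitor, a lower number a stronger inhibitor. In this assay compound 3 gives 28700 nM, the second highest of the three numbers. Its nearest neighbour is compound 1 `COc1ccc(/C=C/C[C@@H]2C[C@@H]([C@@H](O)c3ccc(OC)c(OC)c3)CO[C@H]2c2ccc(OC)c(OC)c2)cc1OC`, which in this assay gives 30600 nM; compound 2 `Oc1cccc(/C=C/C[C@H]2C[C@@H]([C@@H](O)c3ccccc3)CO[C@@H]2c2ccccc2)c1` gives 18600 nM, and both of these lie within the scatter of the value for compound 3. Compounds 1 and 3 share all atoms and bonds, and the step of a 1.1-fold lower number from compound 1 to compound 3 (0.03 log units; within the scatter) is within the scatter; given (the fact that compounds 1 and 3 differ only in the configuration as drawn), this step shows that changing two stereo elements left the number essentially unchanged here.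

Compound 4 `COc1ccc(/C=C/C[C@H]2C[C@H]([C@H](O)c3ccc(OC)c(OC)c3)CO[C@@H]2c2ccc(OC)c(OC)c2)cc1OC` has not yet been measured. It differs from compound 3 as follows: the two compounds have the same atoms and bonds and differ only in configuration as drawn: 2 of 5 stereo elements differ; a stereocentre at a saturated ring carbon is drawn R in compound 3 and S in compound 4; a stereocentre at a saturated ring carbon is drawn R in compound 3 and S in compound 4. For the measured compounds named here, the only measured step that bears on a change of this kind is the one from compound 1 to compound 3, which was within the scatter. Compound 4 is therefore expected to stay within the scatter of compound 3, with an expected step of a 1.0-fold lower number from compound 3 to compound 4 (0.01 log units; within the scatter). For compound 4 the estimate in this assay is 28000 nM, with a range from 12000 nM to 65000 nM.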

Compound 4, half-maximal inhibitory concentration: 34600 nM
For compound 4 the middle estimate is 1.2-fold (0.09 log units) below the measured one; low and high end bracket the measured number.
By their numbers in this assay, from the lowest: compounds 2, 3, 1 and 4 (each within the scatter of the next).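

In this assay, the step of a 1.2-fold higher number from compound 3 to compound 4 (0.08 log units; within the scatter) changes two stereocentres at saturated ring carbons, whereas the earlier step changed one at a ring carbon and one at a chain carbon. The step of a 1.1-fold higher number from compound 1 to compound 4 (0.05 log units; within the scatter) extends this to four of the five stereo elements, and the number still stays within the scatter. Configuration at these centres therefore does not separate compounds 1, 3 and 4 in this assay, and the comparison is a clean one: the fact that compounds 1 and 4 differ only in the configuration as drawn

Compound 2 differs from the others in more than one place, so the compounds shown do not isolate the effect of the methoxy groups on the aryl rings. From the compounds shown here alone, whether an amine or a carboxylic acid on those rings would move the number beyond the scatter remains open.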